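The compounds below may be only part of what the source reports. "The series", "measured", "known", "first", "only" and "open" are said of these compounds alone.

Three compounds share one core and differ only in the aromatic group attached to one carbon of that core. In a functional assay on cells (Pituitary gland cell) for antagonist activity at Gonadotropin-releasing hormone receptor (Rattus norvegicus) (on this read-out lower numbers stand for stronger inhibition and higher numbers for weaker inhibition), compound 3 `CC(=O)OCc1cc(C)cc(-c2c(O)nc3cc(Cl)c([N+](=O)[O-])cc3c2OCCC2CCCCN2)c1` gives 45 nM, the lowest of the three numbers; compound 1 `COc1ccc(-c2c(O)nc3cc(Cl)c([N+](=O)[O-])cc3c2OCCC2CCCCN2)cc1OC` gives 600 nM and compound 2 `O=[N+]([O-])c1cc2c(OCCC3CCCCN3)c(-c3ccccc3Cl)c(O)nc2cc1Cl` gives 360 nM. Compound 4 `O=[N+]([O-])c1cc2c(OCCC3CCCCN3)c(-c3cccs3)c(O)nc2cc1Cl` carries the change (thiophen-2-yl in place of 3-(acetoxymethyl)-5-methylphenyl on an aromatic carbon). Among the measured compounds shown here, two measured steps bear on this: replacing the other aryl groups by the group that compound 3 carries gave a 13-fold lower number from compound 1 to compound 3 (1.12 log units; beyond the scatter) and an 8.0-fold lower number from compound 2 to compound 3 (0.90 log units; beyond the scatter). Since compound 4 gives up that group for a smaller aromatic ring, the expected step is in the opposite direction, with a 6.7-fold higher number from compound 3 to compound 4 (0.82 log units; beyond the scatter). Compound 4 is therefore estimated at 300 nM, with a range from 100 nM to 1000 nM.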

Compound 4, half-maximal inhibitory concentration: 220 nM
Estimate against measurement, compound 4: 1.4-fold (0.13 log units) above; measured number inside the range.
By their numbers in this assay, from the lowest: compound 3; then compounds 4, 2 and 1 (each within the scatter of the next, the first and the last beyond it).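

In this assay, thiophen-2-yl at this position gives a 4.9-fold higher number from compound 3 to compound 4 (0.69 log units; beyond the scatter), so this smaller aromatic ring does not keep the low number seen with 3-(acetoxymethyl)-5-methylphenyl. Against the other aryl groups, the same ring gives a 1.6-fold lower number from compound 2 to compound 4 (0.21 log units; within the scatter) and a 2.7-fold lower number from compound 1 to compound 4 (0.44 log units; beyond the scatter), so losing the larger group does not by itself produce the highest number. No measurement here explains these differences.

Going by these compounds, it remains open whether the acetoxymethyl or the methyl group on compound 3 accounts for its low number. A phenyl ring carrying only a hydroxymethyl group or an amine could help to separate these contributions.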